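Capping the chain end with methanesulfonamide on a spiro scaffold

The source may hold more compounds than are shown below. What is called first, only, known or untested is meant among the compounds shown, and "the series" means these compounds.

Measured compounds in an assay on HEK293 cells for displacement of a labelled ligand from NPC1-like intracellular cholesterol transporter 1 (Homo sapiens); a lower number here means a stronger inhibitor, a higher number a weaker inhibitor:
- compound 1 `CC(C)(C)c1ccc(C(=O)N2CCC3(CC2)C(=O)N(CC(=O)NCN)CN3c2ccccc2)cc1`: 26500 nM
- compound 2 `CC(C)(C)c1ccc(C(=O)N2CCC3(CC2)C(=O)N(CC(=O)N2CCCCC2CCO)CN3c2ccccc2)cc1`: 6100 nM
- compound 3 `CC(C)(C)c1ccc(C(=O)N2CCC3(CC2)C(=O)N(CC(=O)NCCN)CN3c2ccccc2)cc1`: 7000 nM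

Among these three, compound 3 sits close to compound 2 and well away from compound 1, as the step of a 3.8-fold lower number from compound 1 to compound 3 (0.58 log units; beyond the scatter) shows. Compound 4 `CC(C)(C)c1ccc(C(=O)N2CCC3(CC2)C(=O)N(CC(=O)NCNS(C)(=O)=O)CN3c2ccccc2)cc1` carries the change (methanesulfonamido in place of aminomethyl on a saturated chain carbon bound to an amide-type nitrogen). Among the compounds with values here, no measured step tests this group. Within the data shown here, the nearest precedent is a 3.8-fold lower number from compound 1 to compound 3 (0.58 log units; beyond the scatter), a change at the same place, and a 4.3-fold lower number from compound 1 to compound 2 (0.64 log units; beyond the scatter) together with a 1.1-fold higher number from compound 2 to compound 3 (0.06 log units; within the scatter) show that varying the chain end shifts the numbers only modestly. A step of about that size, or none beyond the scatter, is therefore expected, with direction uncertain. Compound 4 is estimated at 8000 nM, expected between 2500 nM and 25000 nM, meaning a step of a 1.1-fold higher number from compound 3 to compound 4 (0.06 log units; within the scatter) from compound 3.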

Compound 4, half-maximal inhibitory concentration: 3200 nM
For compound 4 the middle estimate is 2.5-fold (0.40 log units) above the measured one; the range from low to high includes it.
By their numbers in this assay, from the lowest: compounds 4, 2 and 3 (each within the scatter of the next, the first and the last beyond it); then compound 1.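

In this assay the chain end accepts methanesulfonamido in place of aminomethyl, with a 2.2-fold lower number from compound 3 to compound 4 (0.34 log units; beyond the scatter) beyond the scatter, so the lowest numbers here do not depend on an amine at the end of this chain. Methylsulfonyl in place of hydrogen on the amine nitrogen gives an 8.3-fold lower number from compound 1 to compound 4 (0.92 log units; beyond the scatter) as the largest step shown, whereas a 1.9-fold lower number from compound 2 to compound 4 (0.28 log units; within the scatter) stays within the scatter. Nothing measured here explains these steps. Still open, from the compounds shown here alone, is whether a longer chain carrying methanesulfonamido, or an acetamido group or a carboxylic acid at the chain end, would give a lower number still.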